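Inverting one stereocentre from compound 2 to compound 4

The source may report more compounds than this note shows. Statements on the series, on what has been measured and on what is new or still open speak of the compounds shown alone.

Measured so far in a physicochemical assay for solubility, read by HPLC, in simulated intestinal fluid, with a stated time of 16 h, at pH 6.5; a higher number here means a more soluble compound, a lower number a less soluble compound
Compound 1 `CNC(=O)c1cc(C(=O)N[C@H]2CC[C@H](O)CC2)c([C@@H](C)c2cccc(Cl)c2)o1` gives 408 ug/mL
Compound 2 `CNC(=O)c1cc(C(=O)NC2CC2)cn([C@H](C)c2ccccc2)c1=O` gives 815 ug/mL
Compound 3 `CNC(=O)c1cc(C(=O)N[C@H]2CC[C@H](O)CC2)c([C@@H](C)c2ccccc2Cl)o1` gives > 1000 ug/mL

In this assay compound 2 gives 815 ug/mL and compound 1 gives 408 ug/mL and these two numbers lie within the usual scatter of each other. Compound 3 stands at > 1000 ug/mL as a limit of the assay and not a number.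

The change from compound 2 to the unmeasured compound 4 `CNC(=O)c1cc(C(=O)NC2CC2)cn([C@@H](C)c2ccccc2)c1=O` is one of configuration only (the two compounds have the same atoms and bonds and differ only in configuration as drawn: 1 of 1 stereo elements differ; a stereocentre at a saturated chain carbon is drawn R in compound 2 and S in compound 4) and nothing leaves or enters. Among the compounds with values here, the one measured step (an at least 2.4-fold higher number from compound 1 to compound 3 (0.38 log units; beyond the scatter)) puts 2-chlorophenyl in place of 3-chlorophenyl and ends at a limit (the limit of > 1000 ug/mL in this assay, at which 1 of the 3 values shown sits) on a different core from that of compound 2. It is a change of group and not of configuration. Within the data shown here, no measured pair differs in configuration alone, so that step sets no size for this one. With the same atoms and bonds on both sides, no change beyond the scatter is expected (a 1.0-fold lower number from compound 2 to compound 4 (0.01 log units; within the scatter)) in this assay for this pair. The estimate for compound 4 is 800 ug/mL with an expected range from 480 ug/mL to 1250 ug/mL for a single measurement.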

Compound 4, solubility: 699 ug/mL
For compound 4 the middle estimate is 1.1-fold (0.06 log units) above the measured one, and the stated range covers the measured number.
By their numbers in this assay, from the lowest: compounds 1, 4 and 2 (each within the scatter of the next). At a limit, above all of these: compound 3.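

In this assay, inverting the stereocentre at the saturated chain carbon, drawn R in compound 2 and S in compound 4, gives a 1.2-fold lower number from compound 2 to compound 4 (0.07 log units; within the scatter). The earlier compounds offered only a change of group, so this is the first step among those shown that puts a size on a change of configuration, and at this position, on this core, that size stays within the scatter. The comparison isolates configuration, with nothing leaving or entering: the fact that compounds 2 and 4 differ only in the configuration as drawn.

Going by these compounds, compound 3 gives > 1000 ug/mL, a limit and not a number, and the effect of inverting the same kind of stereocentre on its core stays open, as one pair on one core cannot show whether the result carries over. Also open, on these data alone, is what an amine or a carboxylic acid on the phenyl group of compounds 2 and 4 would do to the number in this assay, and whether the two configurations would then still lie within the scatter of each other.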